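The compounds below may be only part of what the source reports. "The series", "measured", "known", "first", "only" and "open" are said of these compounds alone.

Two amides built on one shared core have so far been measured in a functional assay on NCI-H1975 cells (Homo sapiens) for antiproliferative activity, read by CCK-8 assay, with a stated time of 72 h (on this read-out higher numbers stand for weaker inhibition of growth and lower numbers for stronger inhibition of growth), on these cells. There compound 1 (`CCCNC(=O)c1ccc2c(ccn2-c2ncc3c(n2)N(c2ccn(C)n2)C(CC)C(=O)N3C)c1`) gives 11000 nM as its value, and compound 2 (`CCCCNC(=O)c1ccc2c(ccn2-c2ncc3c(n2)N(c2ccn(C)n2)C(CC)C(=O)N3C)c1`) gives 12000 nM as its value. Compound 2 therefore stands level with compound 1, and the pair offers no ordering. Compound 3 (`CCNC(=O)c1ccc2c(ccn2-c2ncc3c(n2)N(c2ccn(C)n2)C(CC)C(=O)N3C)c1`) has not yet been measured. It differs from compound 2 by hydrogen in place of ethyl on a saturated chain carbon, two bonds along the chain from an amide-type nitrogen in the amide chain, hydrogen in place of ethyl on a saturated chain carbon, two bonds along the chain from an amide-type nitrogen, so that butyl becomes ethyl. Among the measured compounds shown here, only one measured step bears on this change, and it is small (a 1.1-fold higher number from compound 1 to compound 2 (0.04 log units; within the scatter)). It lies three bonds along the same chain, so it is a near neighbour of the new change and not the same one. A single step sets no trend, and no chain as short as ethyl has been measured yet. Even so, a step estimated at a 1.1-fold lower number from compound 2 to compound 3 (0.04 log units; within the scatter) is expected, with no shift beyond the scatter in either direction. For compound 3 the estimated value is 11000 nM with an expected range of (6000 nM to 20000 nM).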

Compound 3, concentration for 50% growth inhibition: "not active" (no number reported)
No number was reported for compound 3; the estimate stays without a comparison.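

In this assay, among the compounds shown here, compound 3 is reported only as "not active", with no number, so no step from compound 2 to compound 3 can be read. The compounds shown leave open how ethyl in place of butyl on the amide chain compares numerically with the other two amides. No further evidence bears on this result.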